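The source may hold more compounds than are shown below. What is called first, only, known or untested is meant among the compounds shown, and "the series" means these compounds.

- Compound 1 `Clc1ccc(-c2nnc(SCCCN3CCN(c4nc5ccccc5o4)CC3)o2)cc1` gives 101000 nM
- Compound 2 `COc1ccc(-c2nnc(SCCCN3CCN(c4nc5ccccc5s4)CC3)o2)cc1` gives 165000 nM
- Compound 3 `Cc1ccc(-c2nnc(SCCCN3CCN(c4nc5ccccc5s4)CC3)o2)cc1` gives 179000 nM

In a functional assay on HeLa cells (Homo sapiens) for inhibition, read by MTT assay, with a stated time of 72 h (a higher number here means a weaker inhibitor, a lower number a stronger inhibitor), compound 3 gives 179000 nM and stands together with compounds 1 and 2. All three values lie within the usual scatter of one another, so no order among them can be read.

Compound 4 `Clc1ccc(-c2nnc(SCCCN3CCN(c4nc5ccccc5s4)CC3)o2)cc1` differs from compound 3 in one place. The difference is counted as chloro in place of methyl on an aromatic carbon and in words it is chloro in place of methyl on an aromatic carbon, para to a large group, which turns 4-methylphenyl to 4-chlorophenyl.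

Going by the values given here, one measured step bears directly on this kind of swap. It shows a 1.1-fold higher number from compound 2 to compound 3 (0.04 log units; within the scatter) for methyl in place of methoxy on an aromatic carbon, so that exchange left the number inside the scatter. Compound 1 already carries 4-chlorophenyl, on a different core, and gives 101000 nM in the same range as the others.

On this evidence, no change beyond the scatter is expected in this assay here. The expected size is a 1.2-fold lower number from compound 3 to compound 4 (0.08 log units; within the scatter) and this is only an estimate. For compound 4 the estimated value is 150000 nM with an expected range from 85000 nM to 260000 nM in this measurement.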

Compound 4, half-maximal inhibitory concentration: 177000 nM
Beside the measured number, compound 4's estimate is 1.2-fold (0.07 log units) below it; the range from low to high includes it.
By their numbers in this assay, from the lowest: compounds 1, 2, 4 and 3 (each within the scatter of the next).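

In this assay, the step from methyl to chloro on the aromatic carbon gives a 1.0-fold lower number from compound 3 to compound 4 (0.00 log units; within the scatter), and the matching step from methoxy gives a 1.1-fold higher number from compound 2 to compound 4 (0.03 log units; within the scatter). Together with the earlier 1.1-fold higher number from compound 2 to compound 3 (0.04 log units; within the scatter), this means that methoxy, methyl and chloro can now all be compared directly at this place on the same core, and no exchange among them moves the number beyond the scatter. Going by these compounds alone, compound 4 also gives the first comparison for the group on the ring amine nitrogen, where 1,3-benzothiazol-2-yl in place of 1,3-benzoxazol-2-yl gives a 1.8-fold higher number from compound 1 to compound 4 (0.24 log units; within the scatter), again within the scatter, and no measurement is available to explain any of these results.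

The compounds shown leave open whether an amine or a carboxylic acid at this place on the six-membered aromatic ring would shift the number beyond the scatter. They also leave open whether a longer chain in the linking part of the core, or a different group in place of the two fused ring systems compared here, would change the reading in this assay.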